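Replacing (tert-butyl)amino with oxetan-3-yl on a sulfonyl sulfur

The source may report more compounds than this note shows. Statements on the series, on what has been measured and on what is new or still open speak of the compounds shown alone.

Measured so far in an ADME assay on microsomes from liver (Mus musculus) for metabolic stability, read by LC-MS, with a stated time of 40 min, tested at 0.5 uM; on this read-out lower numbers stand for slow clearance and higher numbers for fast clearance:
- compound 1 `CC(C)(C)NS(=O)(=O)c1cccc(NC(=O)c2ccc(NS(C)(=O)=O)cc2N2CCC3(CC2)CC3)c1` gives 81 mL.min-1.g-1
- compound 2 `CC(C)(C)NS(=O)(=O)c1cccc(NC(=O)c2cccnc2N2CCC3(CC2)CC3)c1` gives > 399 mL.min-1.g-1 (a limit)
- compound 3 `CC1(C)CCN(c2ncccc2C(=O)Nc2cccc(S(=O)(=O)C3CCCC3)c2)CC1` gives > 399 mL.min-1.g-1 (a limit)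

Compound 1 is the only one of the three with a number. Compound 2 has no number of its own and is known only through a limit (the limit of > 399 mL.min-1.g-1 in this assay, at which 2 of the 3 values shown sit). The size of its clearance is therefore open, and any step starting from it is uncertain.

Compound 4 `O=C(Nc1cccc(S(=O)(=O)C2COC2)c1)c1cccnc1N1CCC2(CC1)CC2` has not yet been measured. It differs from compound 2 in one place (oxetan-3-yl in place of (tert-butyl)amino on a sulfonyl sulfur), with oxetan-3-yl in place of (tert-butyl)amino on a sulfonyl sulfur. No measured pair among these compounds shows what this change does in this assay, so the expectation is a cautious one.

Compound 3 also stands at a limit (> 399 mL.min-1.g-1), which argues against expecting a large drop. A moderate fall in clearance is expected, and the estimated step is an at least 1.5-fold lower number from compound 2 to compound 4 (0.20 log units; that floor lies within the scatter) (an expectation only, since the starting point is a limit). The result could still come back as a limit. For compound 4 the expected value is 250 mL.min-1.g-1 (estimated range 110 mL.min-1.g-1 to 450 mL.min-1.g-1).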

Compound 4, intrinsic clearance in microsomes: 385 mL.min-1.g-1
The estimate for compound 4 lay 1.5-fold (0.19 log units) below the measured number, and the stated range covers the measured number.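

In this assay compound 4 gives 385 mL.min-1.g-1, which is a number and not a limit, so the place on the sulfonyl sulfur now has a measured clearance to work from. Oxetan-3-yl in place of (tert-butyl)amino reads as an at least 1.0-fold lower number from compound 2 to compound 4 (0.01 log units; that floor lies within the scatter), so this change has not been shown to lower clearance by more than the usual scatter of the assay, even though it takes away the hydrogen-bond donor of the group that leaves. The true size of the step remains unknown because the starting value is only a limit: the limit of > 399 mL.min-1.g-1 in this assay, at which 2 of the 4 values shown sit.

The compounds shown leave open whether another group on the sulfonyl sulfur, such as a morpholine or an azetidine, would bring clearance clearly under that of compound 4. They also leave open whether oxetan-3-yl in place of (tert-butyl)amino would act in the same way on the core of compound 1, where the starting clearance is a number and a step could be read in full.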